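A few compounds are considered here, and "the series" means these few. Any claim that something is new, unique, unknown or untested is made for them only; others in the source may bear on it.

Measured compounds:
compound 1, `CCCCCCCCCC(CCO)n1cnc2c(NC)ncnc21`, 5410 nM in a functional assay on HCT-116 cells (Homo sapiens) for antiproliferative activity, read by MTT assay, with a stated time of 48 h; on this read-out higher numbers stand for weaker inhibition and lower numbers for stronger inhibition
compound 2, `CCCCCCCCCC(CCO)n1cnc2c(N)ncnc21`, 10500 nM in this assay
compound 3, `CCCCCCCCCCC(CCO)n1cnc2c(NC)ncnc21`, 12700 nM in this assay

Compound 4, `CCCCCCCCCCC(CCO)n1cnc2c(N(C)C)ncnc21`, is not yet measured. It differs from compound 3 by methyl in place of hydrogen on a nitrogen on an aromatic ring. The same kind of change has been made once before, from compound 2 to compound 1, as methyl in place of hydrogen on a nitrogen on an aromatic ring, where the step was a 1.9-fold lower number from compound 2 to compound 1 (0.29 log units; within the scatter). The surroundings of the place are not identical: in compound 2 the nitrogen carries only an aromatic carbon as other neighbour, whereas in compound 3 it carries an aromatic carbon and a saturated chain carbon. The difference between the cores of compound 2 and compound 3 is not broken down here. The other measured step is a 2.3-fold higher number from compound 1 to compound 3 (0.37 log units; beyond the scatter).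

Resting on the earlier step for compound 2 to compound 1, a similar, small step is expected for compound 4, a 1.4-fold lower number from compound 3 to compound 4 (0.15 log units; within the scatter). Compound 4 is estimated at 9000 nM, between 4000 nM and 25000 nM.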

Compound 4, half-maximal inhibitory concentration: 5490 nM
Compound 4: middle estimate off by 1.6-fold (0.21 log units), on the high side; measured number inside the range.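

In this assay, methyl in place of hydrogen on a nitrogen on an aromatic ring gives a 2.3-fold lower number from compound 3 to compound 4 (0.36 log units; beyond the scatter), and the change behaves alike on the two cores: the same change on two cores in this assay, a 1.9-fold lower number (0.29 log units; within the scatter) from compound 2 to compound 1 and a 2.3-fold lower number (0.36 log units; beyond the scatter) from compound 3 to compound 4, 1.2-fold (0.08 log units) apart, within the scatter of two such steps. On these two cores the step therefore carries over in direction and size, although the nitrogen already bears a methyl group in one starting compound and none in the other. Within the data shown here, only two pairs stand behind this, and one of those steps lies within the scatter, so no general rule for the series follows and the reason for the step remains unknown.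

Open, going by these compounds, is whether an ethyl group or a morpholine ring at that nitrogen keeps the step. Also open, on these data alone, is whether it survives on a shorter chain, or with a carboxylic acid in place of the alcohol.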